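A ring swap on compound 2, at the assay limit

A few compounds are considered here, and "the series" means these few. Any claim that something is new, unique, unknown or untested is made for them only; others in the source may bear on it.

Measured in a functional assay on HL-60 cells (Homo sapiens) for antiproliferative activity, with a stated time of 72 h; a higher number here means a weaker inhibitor, a lower number a stronger inhibitor:
- compound 1 `Nc1ncnn2c([C@@H]3O[C@H](CO)[C@@H](O)[C@H]3O)cc(-c3ccccc3)c12`: > 100000 nM (a limit)
- compound 2 `COc1ccc(-c2cc([C@@H]3O[C@H](CO)[C@@H](O)[C@H]3O)n3ncnc(N)c23)cc1`: > 100000 nM (a limit)

Compound 2 has no exact number, only the limit > 100000 nM. Both measured compounds share this position: the limit of > 100000 nM in this assay, at which 2 of the 2 values shown sit. Within the data shown here, the only measured step is a step that the two limits leave unreadable from compound 1 to compound 2, so it offers no size to carry forward.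

Compound 3 `Cc1ccccc1-c1cc([C@@H]2O[C@H](CO)[C@@H](O)[C@H]2O)n2ncnc(N)c12` has 2-methylphenyl in place of 4-methoxyphenyl on an aromatic carbon. Since compound 2 rests at the limit > 100000 nM, no clear gain in this assay is expected from this swap. The estimated change is a number no higher from compound 2 to compound 3 (the limit leaves the size open), expected to stay within the usual scatter. For compound 3 the estimated value is 100000 nM, with an expected range from 30000 nM to 200000 nM.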

Compound 3, half-maximal inhibitory concentration: 48400 nM
The estimate for compound 3 lay 2.1-fold (0.32 log units) above the measured number; the measured number falls inside the stated range.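

Among these compounds, compound 3 is the first compound here to give an exact number in this assay, which shows that a change on this aromatic carbon can bring the series within measurable range. Placing 2-methylphenyl in place of 4-methoxyphenyl gives an at least 2.0-fold lower number from compound 2 to compound 3 (0.31 log units; beyond the scatter), while adding only the methyl to the phenyl group gives an at least 2.0-fold lower number from compound 1 to compound 3 (0.31 log units; beyond the scatter). The true size of both steps remains unknown because each starts from a limit, not an exact number: the limit of > 100000 nM in this assay, at which 2 of the 3 values shown sit.

The compounds shown do not separate the effect of having a methyl group from the effect of where it sits on the phenyl ring. They also leave open whether an amine or a carboxylic acid on that ring would lower the number further, or raise it.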